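The source may hold more compounds than are shown below. What is called first, only, known or untested is meant among the compounds shown, and "the series" means these compounds.

Measured so far in an ADME assay for permeability, using PAMPA; on this read-out higher numbers stand for higher permeability and lower numbers for lower permeability:
compound 1 `CN(CCN1CCCCC1)c1ccc(Cn2c(=O)[nH]c3c(N)nc(C(F)(F)F)cc32)cn1` gives 5.2 10^-6 cm/s;
compound 2 `CN1CCN(c2ccc(Cn3c(=O)[nH]c4c(N)nc(C(F)(F)F)cc43)cn2)CC1` gives 12 10^-6 cm/s.

Going by the values given here, compound 2 holds the higher of the two numbers measured in this assay, and the only measured step, a 2.3-fold higher number from compound 1 to compound 2 (0.36 log units; beyond the scatter), separates it from compound 1. Among the compounds with values here, that step swaps an acyclic aminoalkyl chain on the aromatic carbon for a ring and is the sole guide for what follows.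

Compound 3 `CN(C)CCNc1ccc(Cn2c(=O)[nH]c3c(N)nc(C(F)(F)F)cc32)cn1` has not yet been measured in this assay. It differs from compound 2 in one place: (2-(dimethylamino)ethyl)amino in place of 4-methylpiperazin-1-yl on an aromatic carbon. The entering group is again an acyclic chain carrying a basic nitrogen, of the same kind as the group that compound 1 carries, though shorter and with one hydrogen-bond donor, so the change runs back along the direction of a 2.3-fold higher number from compound 1 to compound 2 (0.36 log units; beyond the scatter). Within the data shown here, on that basis a modest drop from compound 2, rather than a gain, is the expected outcome, though the donor in the entering group has no measured counterpart here, which widens the range.

Compound 3 is therefore expected to show a step of a 2.0-fold lower number from compound 2 to compound 3 (0.30 log units; within the scatter) in this assay, giving an estimated 6 10^-6 cm/s, within a range from 2.5 10^-6 cm/s to 12 10^-6 cm/s.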

Compound 3, apparent permeability in the ADME assay: 0.1 10^-6 cm/s
Compound 3: middle estimate off by 60-fold (1.78 log units), on the high side; measured number outside the range, below it.
By their numbers in the ADME assay, from the lowest: compound 3; then compound 1; then compound 2.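

In the ADME assay the result shows that this position, on an aromatic carbon next to the ring nitrogen, can carry a far wider spread of numbers than the first step suggested, with a 120-fold lower number from compound 2 to compound 3 (2.08 log units; beyond the scatter) and a 52-fold lower number from compound 1 to compound 3 (1.72 log units; beyond the scatter). Being an acyclic chain is therefore not enough to place a compound here, as the chains of compound 1 and compound 3 lie far apart, and this change also brings in a hydrogen-bond donor that 4-methylpiperazin-1-yl lacks. In a physicochemical assay for solubility, measured as thermodynamic solubility (on this read-out higher numbers stand for higher solubility and lower numbers for lower solubility), compound 2 gives 317 ug/mL and compound 3 gives 483 ug/mL, which is a 1.5-fold higher number from compound 2 to compound 3 (0.18 log units; within the scatter), so the large step in the ADME assay has no counterpart beyond the scatter in this one, and nothing available accounts for that large step.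

Compound 3 differs from compound 2 in both the open chain and the donor, so the compounds shown leave open which of the two goes with the low number. Methyl(2-(dimethylamino)ethyl)amino at this place would keep the chain without the donor, and a morpholin-4-yl ring would test how much the ring's second nitrogen matters.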